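Swapping the dipropylamino group for a trifluoromethyl-piperidine

The compounds below may be only part of what the source reports. "The series", "measured", "known", "first", "only" and "open" are said of these compounds alone.

The series was characterised in a functional assay on CHO-K1 cells for antagonist activity at transient receptor potential cation channel subfamily V member 1 (Homo sapiens), read by FLIPR; a lower number here means a stronger inhibitor, a higher number a weaker inhibitor. Compound 1, with the structure `CCCN(CCC)c1nc(C(F)(F)F)ccc1CNC(=O)C(C)c1ccc(NS(C)(=O)=O)c(F)c1`, gives 0.2 nM in this assay, the lowest of the two numbers recorded; compound 2, with the structure `C[C@H](C(=O)NCc1ccc(C(F)(F)F)nc1N1CCC(c2ccccc2)CC1)c1ccc(NS(C)(=O)=O)c(F)c1`, gives 0.3 nM in this assay, and the two values lie within the scatter of each other, so no order between them can be claimed. Compound 3, with the structure `CC(C(=O)NCc1ccc(C(F)(F)F)nc1N1CCC(C(F)(F)F)CC1)c1ccc(NS(C)(=O)=O)c(F)c1`, has not yet been measured in this assay. It differs from compound 1 by a single change: 4-(trifluoromethyl)piperidin-1-yl in place of dipropylamino on an aromatic carbon. For the measured compounds named here, no step between measured compounds that differ in one place is available. Since compound 2 also carries a piperidine at this position and gives 0.3 nM, a step of no more than the usual scatter is expected. For compound 3 a value of 0.4 nM is estimated, within 0.1 nM to 1.5 nM, corresponding to an expected 2.0-fold higher number from compound 1 to compound 3 (0.30 log units; within the scatter).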

Compound 3, inhibition constant: 0.6 nM
Compound 3: middle estimate off by 1.5-fold (0.18 log units), on the low side; the range from low to high includes it.
By their numbers in this assay, from the lowest: compounds 1, 2 and 3 (each within the scatter of the next, the first and the last beyond it).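

Putting 4-(trifluoromethyl)piperidin-1-yl in place of dipropylamino on this aromatic carbon next to the ring nitrogen gives a 3.0-fold higher number from compound 1 to compound 3 (0.48 log units; beyond the scatter) in this assay. The step is modest but beyond the scatter, so this position does respond to the exchange, and the first measured single change there shows that the open dipropylamino group can give way to a six-membered non-aromatic ring at a limited cost in this pair. The data offer no measurement that explains the step.

The change brings in the ring and its trifluoromethyl group together, so the pair cannot show which of the two goes with the step. Unsubstituted piperidine would separate them, while morpholine or diethylamino would show how far the position tolerates other amines.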